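The compounds below may be only part of what the source reports. "The series", "measured", "known", "first", "only" and "open" are said of these compounds alone.

For the measured compounds named here, in a functional assay on G-361 cells (Homo sapiens) for inhibition, with a stated time of 72 h (a lower number here means a stronger inhibitor, a higher number a weaker inhibitor), compound 1 `NC1CCC(Nc2nc(NCc3ccc(-c4ccsc4)cc3)c3ncn(C4CCCC4)c3n2)CC1` gives 570 nM and compound 2 `NC1CCC(Nc2nc(NCc3ccc(-c4ccccc4)nc3)c3ncn(C4CCCC4)c3n2)CC1` gives 895 nM, so compound 2 stands within the scatter of the only other measured value. Compound 3 `NC1CCC(Nc2nc(NCc3ccc(-c4ccco4)nc3)c3ncn(C4CCCC4)c3n2)CC1` carries furan-2-yl in place of phenyl on an aromatic carbon. Going by the values given here, one measured step bears on this, the exchange of 4-(thiophen-3-yl)phenyl for 6-phenylpyridin-3-yl, a 1.6-fold higher number from compound 1 to compound 2 (0.20 log units; within the scatter), which stayed within the scatter. No shift beyond the scatter is therefore expected, and the estimated change is a 1.3-fold lower number from compound 2 to compound 3 (0.11 log units; within the scatter). For compound 3 the expected value is 700 nM, with an estimated range of 250 nM to 2000 nM.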

Compound 3, half-maximal inhibitory concentration: 97 nM
Beside the measured number, compound 3's estimate is 7.2-fold (0.86 log units) above it; the whole stated range lies above it.
By their numbers in this assay, from the lowest: compound 3; then compounds 1 and 2 (each within the scatter of the next).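

In this assay, for the compounds shown here, the aromatic carbon next to the ring nitrogen proves sensitive to the group it carries: furan-2-yl in place of phenyl gives a 9.2-fold lower number from compound 2 to compound 3 (0.97 log units; beyond the scatter), the first step beyond the scatter. The larger exchange of 4-(thiophen-3-yl)phenyl for 6-(furan-2-yl)pyridin-3-yl gives a 5.9-fold lower number from compound 1 to compound 3 (0.77 log units; beyond the scatter), which sets compound 3 apart from both earlier compounds. Nothing available accounts for this shift.

Open, on these data alone, is whether the shift is specific to furan-2-yl or extends to thiophen-2-yl, or to a small group such as methyl or an amine, at that carbon.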